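The source may report more compounds than this note shows. Statements on the series, on what has been measured and on what is new or still open speak of the compounds shown alone.

Series notes on the step from compound 1 to compound 4. Compound 1 `COc1cc(N)c(Cl)cc1NC(=O)C1CCN(CC2CC2)CC1` is the reference point for a functional assay on the whole organism for antagonist activity, with Mus musculus as the target; on this read-out higher numbers stand for an effect only at larger amounts of compound and lower numbers for an effect already at smaller amounts. In this assay compound 1 gives > 10 mg/kg, which is a limit of the assay and not a number. Compound 2 `COc1cc(N)c(Cl)cc1NC(=O)C1CCN(Cc2ccccc2Cl)CC1` gives > 4 mg/kg in this assay, again only a limit. Compound 3 `COc1cc(N)c(Cl)cc1NC(=O)C1CCN(Cc2cccc(C#N)c2)CC1` gives > 4 mg/kg in this assay, also a limit. Among the measured compounds shown here, the steps a step that the two limits leave unreadable from compound 1 to compound 2 and a step that the two limits leave unreadable from compound 1 to compound 3 bear on the change in hand but cannot be sized, since the limit of > 10 mg/kg in this assay, at which 1 of the 3 values shown sits, and the limit of > 4 mg/kg in this assay, at which 2 of the 3 values shown sit, bound every value so far. Compound 4 `COc1cc(N)c(Cl)cc1NC(=O)C1CCN(Cc2ccccc2F)CC1` carries the change (2-fluorophenyl in place of cyclopropyl on a saturated chain carbon bound to an amine nitrogen in a ring). With nothing readable behind it, the estimated step of an at least 1.4-fold lower number from compound 1 to compound 4 (0.15 log units; that floor lies within the scatter) is set near zero, with no direction expected beyond the scatter. Compound 4 is therefore expected to give 7 mg/kg in this assay, within 3 mg/kg to 25 mg/kg, and most likely again reported only as a limit.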

Compound 4, dose for half-maximal effect: > 4 mg/kg
Compound 4 was reported as a limit; the forecaster's own chance of this, stated with the estimate: 70%; the middle value does not contradict the limit.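

Among the compounds shown here, compound 4, like compound 1, compound 2 and compound 3, is reported only as a limit in this assay, so no step among them can be read. The compounds shown leave open how these groups rank on the amine nitrogen in a ring.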